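4-methylphenyl on the ring nitrogen of compound 1

The source may hold more compounds than are shown below. What is called first, only, known or untested is meant among the compounds shown, and "the series" means these compounds.

In a functional assay on HeLa cells (Homo sapiens) for antiproliferative activity, read by MTT assay, with a stated time of 72 h (a higher number here means a weaker inhibitor, a lower number a stronger inhibitor), compound 1 (`O=C1COc2ccc(-c3cccc(NS(=O)(=O)c4ccc(F)cc4)c3)cc2N1`) stands at > 40000 nM as a limit of the assay, not a number. Compound 4 (`Cc1ccc(N2C(=O)COc3ccc(-c4cccc(NS(=O)(=O)c5ccc(F)cc5)c4)cc32)cc1`) has 4-methylphenyl in place of hydrogen on an amide-type nitrogen in a ring. For the measured compounds named here, no measured step isolates this change. Compound 2 (`COc1ncc(-c2ccc3c(c2)N(C2CCCCC2)C(=O)CO3)cc1NS(=O)(=O)c1ccc(F)cc1`) gives 6100 nM and compound 3 (`O=C1COc2ccc(-c3cnc(Cl)c(NS(=O)(=O)c4ccc(F)cc4)c3)cc2N1C1CC1`) gives 7180 nM as measured numbers. Both carry a substituent on that nitrogen but also differ from compound 1 elsewhere, so they are only a loose guide. The expected at least 4.0-fold lower number from compound 1 to compound 4 (0.60 log units; beyond the scatter) runs toward stronger inhibition, beyond the scatter. For compound 4 the estimated value is 10000 nM with an expected range from 3000 nM to 35000 nM in this assay for now.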

Compound 4, half-maximal inhibitory concentration: > 40000 nM
Compound 4 gave a limit, no number; the forecaster's own chance of this, stated with the estimate: 25%; at least 4.0-fold (0.60 log units) between middle value and limit.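

Compound 1 and compound 4 both stand at a limit in this assay and no step can be read between them: the limit of > 40000 nM in this assay, at which 2 of the 4 values shown sit.

The compounds shown leave open what 4-methylphenyl in place of hydrogen on the amide-type nitrogen in a ring does on its own.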